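This account rests on a few compounds, and the source may have more. Where it says the series, first, only, none or still open, it means among the compounds named here.

Working notes on the series. Among the compounds with values here, compound 3, `Cc1ccc(OCC(=O)N2CCN(c3ccc(C(F)(F)F)cc3[C@@H](N)CC(C)C)CC2)c(C)c1`, stands second highest of the three numbers so far in an assay on HEK293 cells for displacement of a labelled ligand from Melanocortin receptor 4 (Homo sapiens) (a higher number here means a weaker inhibitor, a lower number a stronger inhibitor), giving 4000 nM. Its nearest neighbour is compound 2, `CC(C)C[C@H](N)c1cc(C(F)(F)F)ccc1N1CCN(C(=O)COc2ccc(O)cc2)CC1`, which gives 4600 nM; the pair differ by a 1.2-fold lower number from compound 2 to compound 3 (0.06 log units; within the scatter). Furthest is compound 1, `CC(C)C[C@H](N)c1cc(C(F)(F)F)ccc1N1CCN(C(=O)COc2ccc3ccccc3c2)CC1`, which gives 2000 nM; the step of a 2.0-fold higher number from compound 1 to compound 3 (0.30 log units; within the scatter) lies within the scatter, while a 2.3-fold higher number from compound 1 to compound 2 (0.36 log units; beyond the scatter) is a modest step beyond it.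

Compound 4, `Cc1ccc(CC(C)C(=O)N2CCN(c3ccc(C(F)(F)F)cc3[C@@H](N)CC(C)C)CC2)cc1C`, is not yet measured. It differs from compound 3 by 1-(3,4-dimethylbenzyl)ethyl in place of (2,4-dimethylphenoxy)methyl on a carbonyl carbon. Within the data shown here, every measured step swaps the aromatic group on an oxygen on a saturated carbon and keeps that oxygen; none removes the oxygen or places 1-(3,4-dimethylbenzyl)ethyl on the carbonyl carbon, so no measured step bears directly on this change. The aryl swaps seen so far moved this assay by at most the modest 2.3-fold higher number from compound 1 to compound 2 (0.36 log units; beyond the scatter), and the others stayed within the scatter. A change of comparable size is expected here, direction uncertain, so the step from compound 3 to compound 4 is estimated at a 1.3-fold higher number from compound 3 to compound 4 (0.10 log units; within the scatter). For compound 4 the expected value in this assay is 5000 nM, with a range from 1500 nM to 16000 nM.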

Compound 4, inhibition constant: 240 nM
Beside the measured number, compound 4's estimate is 21-fold (1.32 log units) above it, and the stated range ends above it.
By their numbers in this assay, from the lowest: compound 4; then compounds 1, 3 and 2 (each within the scatter of the next, the first and the last beyond it).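

Within the data shown here, the step to 1-(3,4-dimethylbenzyl)ethyl on the carbonyl carbon is the only large kind of change so far: in this assay there is a 17-fold lower number from compound 3 to compound 4 (1.22 log units; beyond the scatter) and likewise a 19-fold lower number from compound 2 to compound 4 (1.28 log units; beyond the scatter) as the group replaces the two phenoxymethyl groups. The naphthalen-2-yl ether gives a smaller but still clear step, an 8.3-fold lower number from compound 1 to compound 4 (0.92 log units; beyond the scatter) and so the three ethers all lie well on the weaker side of the new group. This position therefore tolerates loss of the ether oxygen, and it responds to a change in the group on the carbonyl carbon far more than the aryl swaps on that oxygen suggested, though no measured data here explain the gain.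

Among these compounds, the single change replaces the oxygen, adds a carbon branch and moves from a 2,4-dimethylphenyl to a 3,4-dimethylbenzyl pattern all at once, so the share of each remains unresolved. An unbranched chain to the same 3,4-dimethylphenyl ring, or an amine in place of the ether oxygen, would separate these contributions.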